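This account rests on a few compounds, and the source may have more. Where it says the series, first, only, none or still open, it means among the compounds named here.

Measured compounds in the series so far:
Compound 1, `O=C(Nc1ccc(Cl)c(-c2nnc3c(Cl)cccn23)c1)c1ccccc1`. In a functional assay on MCF7 cells (Homo sapiens) for antiproliferative activity, read by MTT assay, with a stated time of 72 h (a higher number here means a weaker inhibitor, a lower number a stronger inhibitor), compound 1 gives > 100000 nM, which is a limit of the assay and not a number.
Compound 2, `O=C(Nc1ccc(Cl)c(-c2nnc3c(Cl)cccn23)c1)c1ccc(Cl)cc1`. In this assay compound 2 gives 58400 nM.
Compound 3, `O=C(Nc1ccc(Cl)c(-c2nnc3c(Cl)cccn23)c1)c1ccc(C(F)(F)F)cc1Cl`. In this assay compound 3 gives 81600 nM.

Compound 2 holds the lowest of the two numbers, but compound 3 sits within the scatter of it, so no order between these two is claimed. Going by the values given here, the only step measured within one change is an at least 1.7-fold lower number from compound 1 to compound 2 (0.23 log units; that floor lies within the scatter); it can only be read against (the limit of > 100000 nM in this assay, at which 1 of the 3 values shown sits), so its true size is unknown beyond that floor. Compound 3 adds a second chloro and a trifluoromethyl to the benzoyl ring of compound 2 without moving the number beyond the scatter.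

Compound 4, `CS(=O)(=O)c1cccc(C(=O)Nc2ccc(Cl)c(-c3nnc4c(Cl)cccn34)c2)c1`, differs from compound 2 by 3-(methylsulfonyl)phenyl in place of 4-chlorophenyl on a carbonyl carbon. Among the compounds with values here, no measured step exchanges the whole aryl group, so the expectation rests only on the small spread seen across compounds 2 and 3 and the weak step from compound 1. A step of a 1.2-fold higher number from compound 2 to compound 4 (0.08 log units; within the scatter) is expected, which is no change beyond the scatter, with some chance that only a limit is returned. Compound 4 is estimated at 70000 nM, within 30000 nM to 160000 nM.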

Compound 4, half-maximal inhibitory concentration: 88900 nM
Compound 4: the middle estimate sits 1.3-fold (0.10 log units) below what was measured; the range from low to high includes it.
By their numbers in this assay, from the lowest: compounds 2, 3 and 4 (each within the scatter of the next). At a limit, above all of these: compound 1.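

In this assay, going by these compounds alone, the exchange on the carbonyl carbon gives a 1.5-fold higher number from compound 2 to compound 4 (0.18 log units; within the scatter), the first measured step that replaces the whole aryl group. The entering 3-(methylsulfonyl)phenyl counts 2 hydrogen-bond acceptors where the leaving 4-chlorophenyl counts 0, and that difference brings no change beyond the scatter. Compound 1 stands at a limit and not at a number, so the remaining step, an at least 1.1-fold lower number from compound 1 to compound 4 (0.05 log units; that floor lies within the scatter), gives only a floor and its true size is unknown: the limit of > 100000 nM in this assay, at which 1 of the 4 values shown sits.

Still open, on these data alone, is whether any change to this aryl ring can move the number beyond the scatter, since the compounds with numbers carry only chloro, trifluoromethyl and methylsulfonyl there, and the same group is never compared at two places on the ring. An amine or a carboxylic acid on that ring, or a change to the shared core itself, would show whether the series can leave this narrow band of values.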